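Tolerance notes: compound 3 to compound 4

The source may report more compounds than this note shows. Statements on the series, on what has been measured and on what is new or still open speak of the compounds shown alone.

Measured in an ADME assay on HEK-293T cells (Homo sapiens) for cytotoxicity, read by CCK-8 assay, with a stated time of 24 h; a lower number here means that less compound is tolerated, a higher number that more compound is tolerated:
- compound 1 `O=C(CSc1c[nH]c2ccccc12)NCc1ccccc1` gives > 100000 nM as a limit
- compound 2 `O=C(CSc1c[nH]c2ccc(Br)cc12)NCc1ccc(Cl)c(Cl)c1` gives > 100000 nM as a limit
- compound 3 `COc1ccccc1CNC(=O)CSc1c[nH]c2cccc(Br)c12` gives > 100000 nM as a limit

Compound 3 has no numerical value, only a limit (> 100000 nM). It is no exception in the series, which shows the limit of > 100000 nM in this assay, at which 3 of the 3 values shown sit, and no number for any compound. Within the data shown here, no measured step between two compounds is available, so the series gives no direct size for a structural change.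

The next compound is compound 4 `O=C(CSc1c[nH]c2cccc(Br)c12)NCc1ccc(Cl)c(Cl)c1`. The change is 3,4-dichlorophenyl in place of 2-methoxyphenyl on a saturated chain carbon bound to an amide-type nitrogen and the shared core stays in place. The entering group also stands in compound 2, whose result is likewise a limit (> 100000 nM).

No shift in either direction beyond the usual scatter is expected in this assay for this change. The estimated step of a number no higher from compound 3 to compound 4 (the limit leaves the size open) is therefore expected to be small, and a report of a limit alone is the likeliest outcome. For compound 4 the estimated value is 100000 nM with an expected range from 40000 nM to 200000 nM for the measurement.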

Compound 4, half-maximal cytotoxic concentration: > 100000 nM
Compound 4: only a limit was reported (the forecaster's own chance of this, stated with the estimate: 80%); the middle value sits exactly at the limit.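

In this assay, among these compounds, compound 3 and compound 4 are both reported only as limits, so no step between compound 3 and compound 4 can be read. The compounds shown leave open whether any structural change in the series shifts the tolerated concentration, or by how much, as every result is a limit: the limit of > 100000 nM in this assay, at which 4 of the 4 values shown sit.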